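This account rests on a few compounds, and the source may have more. Where it says the series, first, only, none or still open, it means among the compounds named here.

Measured so far in a functional assay on SW-620 cells (Homo sapiens) for inhibition, read by MTT assay, with a stated time of 72 h; on this read-out lower numbers stand for stronger inhibition and higher numbers for weaker inhibition:

compound 1 `COc1cc(NC(C)CCCNC(=O)Nc2cc(C(F)(F)F)cc(C(F)(F)F)c2)c2ncccc2c1` gives 3900 nM
compound 2 `COc1cc(NC(C)CCCNC(=O)Nc2cccc(C(F)(F)F)c2)c2ncccc2c1` gives 22000 nM
compound 3 `COc1cc(NC(C)CCCNC(=O)NNC(=O)Nc2cccc(C(F)(F)F)c2)c2ncccc2c1` gives 21000 nM

Compound 4 `COc1cc(NC(C)CCCNC(=O)NNC(=O)Nc2cc(C(F)(F)F)cc(C(F)(F)F)c2)c2ncccc2c1` has not yet been measured in this assay. It is built from compound 3 by one change, (trifluoromethyl in place of hydrogen on an aromatic carbon), and the same change is already known from one measured pair: compound 1 arises from compound 2 by trifluoromethyl in place of hydrogen on an aromatic carbon. The words describing the surroundings of the place are identical for both pairs, so this is the same change made on two different cores. In that measured pair it produced a 5.6-fold lower number from compound 2 to compound 1 (0.75 log units; beyond the scatter), a step large enough to count as real.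

Compound 2 and compound 3 share the same change-bearing ring but differ in their cores; how the two cores differ is not broken down here. In this assay compound 2 gives 22000 nM, and compound 3 gives 21000 nM; these two numbers lie within the usual scatter of each other, so the read-out does not separate the two cores.

The expectation for compound 4 therefore rests on a single measured instance of the change, a 5.6-fold lower number from compound 2 to compound 1 (0.75 log units; beyond the scatter), carried over to the core of compound 3. Among the measured compounds shown here, the step expected from compound 3 to compound 4 is a 5.3-fold lower number from compound 3 to compound 4 (0.72 log units; beyond the scatter), with wide room for scatter because only one instance, a 5.6-fold lower number from compound 2 to compound 1 (0.75 log units; beyond the scatter), supports it. Compound 4 is thus estimated to give 4000 nM, with a likely range from 1500 nM to 11000 nM.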

Compound 4, half-maximal inhibitory concentration: 16000 nM
The estimate for compound 4 lay 4.0-fold (0.60 log units) below the measured number; measured number above the stated range.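

In this assay, adding a second trifluoromethyl to the ring of compound 3 gives a 1.3-fold lower number from compound 3 to compound 4 (0.12 log units; within the scatter), so on this core the change has no effect that can be told apart from ordinary variation between repeat measurements. Among the compounds shown here, the same change therefore did not carry over with the same size from one core to the other, and the close read-outs of compound 2 and compound 3 did not mean that the two cores would respond alike: the same change on two cores in this assay, a 5.6-fold lower number (0.75 log units; beyond the scatter) from compound 2 to compound 1 and a 1.3-fold lower number (0.12 log units; within the scatter) from compound 3 to compound 4, 4.3-fold (0.63 log units) apart, beyond the scatter of two such steps This rests on only two matched pairs, so it shows that the size of this step depends on the core in this small set, but it does not show which feature of the cores is responsible, or how the change would behave on any further core.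

The compounds shown leave open whether a chlorine atom or a nitrile at the same place on the ring would also give a clear step on the core of compound 1 and almost none on the core of compound 3. They also leave open whether an amine or a carboxylic acid there would separate the two cores in the same way.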